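The compounds below may be only part of what the source reports. "The series", "measured", "known", "first", "only" and "open" are said of these compounds alone.

Working notes on the series. The shared core carries an aryl-urea arm and a benzyl-type arm on the nitrogen that also bears the triazole. Compound 1 `COc1ccc(CN(C(=O)Nc2ccc(Cl)cc2)n2cnnc2)cc1OC` gives 20400 nM in a functional assay on DU-145 cells (Homo sapiens) for cytotoxicity, read by MTT assay, with a stated time of 48 h; on this read-out lower numbers stand for stronger inhibition and higher numbers for weaker inhibition. Compound 3 `CCc1ccc(NC(=O)N(Cc2cc(OC)c(OC)c(OC)c2)n2cnnc2)cc1` gives 21400 nM in this assay; its value and that of compound 1 lie within the scatter of each other. Compound 2 `COc1ccc(CN(C(=O)Nc2ccc(Cl)c(C(F)(F)F)c2)n2cnnc2)cc1OC` reaches only a limit of the measurement, > 50000 nM in this assay, and no number is known for it. The one step measured within the series, an at least 2.4-fold higher number from compound 1 to compound 2 (0.38 log units; beyond the scatter), runs toward the weaker end and ends at the limit, as shown in the limit of > 50000 nM in this assay, at which 1 of the 3 values shown sits.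

Compound 4 `Cc1ccsc1CN(C(=O)Nc1ccc(Cl)c(C(F)(F)F)c1)n1cnnc1` differs from compound 2 in 3-methylthiophen-2-yl in place of 3,4-dimethoxyphenyl on a saturated chain carbon bound to an amide-type nitrogen. For the measured compounds named here, no measured step changes this arm, so the only guidance is that compound 2, which shares the aryl-urea arm of compound 4, already sits at the limit. The step from compound 2 to compound 4 is therefore expected to be a number no higher from compound 2 to compound 4 (the limit leaves the size open), with no direction beyond the scatter that the data would support. Compound 4 is estimated to give 50000 nM, within a range from 20000 nM to 150000 nM, and most likely again only a limit.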

Compound 4, half-maximal inhibitory concentration: 24100 nM
Compound 4: middle estimate off by 2.1-fold (0.32 log units), on the high side; the measured number falls inside the stated range.
By their numbers in this assay, from the lowest: compounds 1, 3 and 4 (each within the scatter of the next). At a limit, above all of these: compound 2.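

The arm on a saturated chain carbon bound to an amide-type nitrogen now has a measured step of its own in this assay: 3-methylthiophen-2-yl in place of 3,4-dimethoxyphenyl gives an at least 2.0-fold lower number from compound 2 to compound 4 (0.31 log units; beyond the scatter). This shows that the value at this position responds to the arm, and that the aryl-urea arm shared by compound 2 and compound 4 does not by itself hold a compound at the limit, which the step from compound 1 to compound 2 alone could not separate. The size of the change remains a lower bound only, because compound 2 has a limit and not a number: the limit of > 50000 nM in this assay, at which 1 of the 4 values shown sits.

The compounds shown leave open whether the step belongs to the five-membered ring, to its methyl or to the loss of the 3,4-dimethoxyphenyl group, which a plain thiophen-2-yl or an unsubstituted phenyl at the same place would help to separate. They also leave open whether 3-methylthiophen-2-yl would change the value in the same direction when paired with the aryl-urea arm of compound 1 or compound 3.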